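Adding 4-Chlorophenyl to the Ring Nitrogen of Compound 1

The source may report more compounds than this note shows. Statements on the series, on what has been measured and on what is new or still open speak of the compounds shown alone.

Measured so far in a functional assay on HCT-116 cells (Homo sapiens) for antiproliferative activity, read by MTT assay, with a stated time of 72 h (a higher number here means a weaker inhibitor, a lower number a stronger inhibitor), are two compounds:
compound 1 (`COc1ncc(-c2ccc3c(c2)NC(=O)CO3)cc1NS(=O)(=O)c1ccc(F)cc1`) gives 24900 nM
compound 2 (`O=C1COc2ccc(-c3cnc(Cl)c(NS(=O)(=O)c4ccc(F)cc4)c3)cc2N1C1CC1`) gives 12400 nM

The value of compound 1 lies within the usual scatter of the value of compound 2, so these two numbers set no order. The two compounds differ in more than one place, and no measured single change is available as a guide. Compound 3 (`COc1ncc(-c2ccc3c(c2)N(c2ccc(Cl)cc2)C(=O)CO3)cc1NS(=O)(=O)c1ccc(F)cc1`) keeps the core of compound 1 and carries one change: 4-chlorophenyl in place of hydrogen on an amide-type nitrogen in a ring. With so little evidence, a moderate step toward stronger inhibition is expected in this assay (a lower number), although a step within the scatter would remain plausible. The estimated change is a 4.2-fold lower number from compound 1 to compound 3 (0.62 log units; beyond the scatter) (an expectation only). Compound 3 is estimated at 6000 nM (expected range 1000 nM to 30000 nM).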

Compound 3, half-maximal inhibitory concentration: 19200 nM
Compound 3: the middle estimate sits 3.2-fold (0.51 log units) below what was measured; measured number inside the range.
By their numbers in this assay, from the lowest: compounds 2, 3 and 1 (each within the scatter of the next).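

In this assay, placing 4-chlorophenyl in place of hydrogen on the amide-type nitrogen in a ring gives a 1.3-fold lower number from compound 1 to compound 3 (0.11 log units; within the scatter), so this single change sets no order between the two compounds. The earlier pair differed in more than one place, whereas this step isolates the ring nitrogen and shows that the amide hydrogen can be replaced by this aromatic ring with no change beyond the scatter in this read-out. No measurement at hand accounts for this result.

On these data alone, it remains open whether a small methyl group, a chain ending in an amine or a carboxylic acid on this nitrogen would shift the number beyond the scatter. The cyclopropyl group of compound 2 also cannot be judged alone, as that compound differs from compound 1 in more than one place.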